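Working notes: 4-methoxyphenyl to phenyl, cytotoxicity

The source may hold more compounds than are shown below. What is called first, only, known or untested is meant among the compounds shown, and "the series" means these compounds.

Measured so far in a functional assay on A549 cells (Homo sapiens) for cytotoxicity, read by MTT assay, with a stated time of 4 days; a lower number here means a stronger inhibitor, a higher number a weaker inhibitor:
compound 1 `C=C1C[C@]23C[C@@]1(O)CC[C@@H]2c1cccc(C)c1[C@@H]3Cn1cc(-c2ccc(C)cc2)nn1` — > 20000 nM
compound 2 `COc1ccc(-c2cn(C[C@H]3c4c(ccc(O)c4C)[C@@H]4CC[C@@]5(C)C[C@]43CC5=O)nn2)cc1` — > 20000 nM

Both values are limits of the assay, not numbers. Compound 1 gives only a limit, > 20000 nM. Compound 2 likewise gives only a limit, > 20000 nM. Going by the values given here, compound 2 therefore stands at the limit of this assay, and so does the one other value shown (the limit of > 20000 nM in this assay, at which 2 of the 2 values shown sit). Among the compounds with values here, no two measured compounds differ in a single place, so no measured step exists in this assay.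

Compound 3 `Cc1c(O)ccc2c1[C@H](Cn1cc(-c3ccccc3)nn1)[C@@]13CC(=O)[C@@](C)(CC[C@@H]21)C3` is not yet measured. It differs from compound 2 by hydrogen in place of methoxy on an aromatic carbon. With compound 2 at a limit, no measured step can be read, and nothing in the two values shown suggests that this change would bring the number inside the range of this assay. The expected step is none beyond the scatter, most likely another limit. Compound 3 is expected at about 25000 nM, between 8000 nM and 80000 nM. That expectation corresponds to a step that the limit leaves unreadable from compound 2 to compound 3.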

Compound 3, half-maximal inhibitory concentration: > 20000 nM
Compound 3: no number, only a limit; the forecaster's own chance of this, stated with the estimate: 80%; the middle value does not contradict the limit.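

In this assay, going by these compounds alone, compound 3 gives > 20000 nM, a limit and not a number; compound 2 also stands at a limit, so no step between compound 2 and compound 3 can be read. The compounds shown leave open how methoxy and hydrogen compare, and whether any member of this series gives a number in this assay.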